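This account rests on a few compounds, and the source may have more. Where it says the series, first, only, none or still open, it means among the compounds named here.

Measured so far, with each compound's half-maximal effective concentration in a functional assay on aorta (Rattus norvegicus, strain Wistar) for inhibition, with a stated time of 60 min; a higher number here means that more compound is needed for the effect, a lower number that less compound is needed:

Compound 1 `CCOc1ccccc1-c1nc2cc([N+](=O)[O-])ccc2[nH]1`: 3710 nM
Compound 2 `FC(F)(F)c1ccc2[nH]c(-c3ccccc3)nc2c1`: 369000 nM
Compound 3 `CC(C)Oc1ccccc1-c1nc2cc([N+](=O)[O-])ccc2[nH]1`: 4890 nM

Compound 2 stands at the highest number of the three, so it needs the most compound for the effect; compound 1 and compound 3 both lie far lower. Compound 4 `Oc1ccc(-c2nc3cc(C(F)(F)F)ccc3[nH]2)cc1` differs from compound 2 in one place: hydroxy in place of hydrogen on an aromatic carbon. Going by the values given here, the only measured step in this set, a 1.3-fold higher number from compound 1 to compound 3 (0.12 log units; within the scatter), concerns a change on a saturated chain carbon rather than on a ring, and it stays within the scatter, so it says little about what a hydroxy on the ring will do. Compound 1 and compound 3 both carry an oxygen on that ring and give far lower numbers than compound 2, but they also carry a nitro group on the shared core where compound 2 carries trifluoromethyl, so the two differences cannot be separated. For compound 4 a moderate move to a lower number is expected, a 2.5-fold lower number from compound 2 to compound 4 (0.39 log units; beyond the scatter), with wide uncertainty. Compound 4 is therefore estimated at 150000 nM in this assay, between 40000 nM and 500000 nM.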

Compound 4, half-maximal effective concentration: 219000 nM
Estimate against measurement, compound 4: 1.5-fold (0.16 log units) below, within the range that was stated.
By their numbers in this assay, from the lowest: compounds 1 and 3 (each within the scatter of the next); then compounds 4 and 2 (each within the scatter of the next).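

In this assay, hydroxy in place of hydrogen on an aromatic carbon, para to a large group, gives a 1.7-fold lower number from compound 2 to compound 4 (0.23 log units; within the scatter), so this change at this position produces no difference that can be told apart from the ordinary spread of repeated measurements. Going by these compounds alone, the earlier compounds could show an oxygen on a ring only alongside a nitro group on the shared core, whereas this pair differs in one place alone, with trifluoromethyl present in both compounds, and so gives the first clean reading of a ring substituent in this set. No supporting measurement is available that bears on this result.

Going by these compounds, it remains open whether a different group at this same position, such as an amine or a carboxylic acid, would produce a step beyond the scatter. On these data alone, it is also open whether hydroxy would give the same small step elsewhere on this ring, or on a compound carrying a nitro group rather than trifluoromethyl on the shared core.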